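The source may report more compounds than this note shows. Statements on the series, on what has been measured and on what is new or still open speak of the compounds shown alone.

Measured so far:
Compound 1, `Cc1c(C=C(CO)CO)n(C)c(=O)[nH]c1=O`, gives > 100000 nM in a functional assay on HepG2 cells (Homo sapiens) for antiproliferative activity, read by MTT assay, with a stated time of 72 h; a lower number here means a stronger inhibitor, a higher number a weaker inhibitor; this is a limit of the assay rather than a number.
Compound 2, `CC(=O)OCC(O)(COC(C)=O)Cc1c(C)c(=O)[nH]c(=O)n1C`, gives > 100000 nM in this assay; this too is a limit.

Compound 2 thus stands only at a limit, with no number of its own, and (the limit of > 100000 nM in this assay, at which 2 of the 2 values shown sit). Compound 3, `CC(=O)OCC(F)(COC(C)=O)Cc1c(C)c(=O)[nH]c(=O)n1C`, differs from compound 2 by fluoro in place of hydroxy on a saturated chain carbon bound to three saturated chain carbons. Among the measured compounds shown here, no measured step spans such a change, so no direction can be drawn from the data; no step beyond the scatter is expected. The expected step is a number no higher from compound 2 to compound 3 (the limit leaves the size open). Compound 3 is therefore estimated at 100000 nM, within 30000 nM to 300000 nM, most likely again reported only as a limit.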

Compound 3, half-maximal inhibitory concentration: > 100000 nM
Compound 3: a limit, no number; the forecaster's own chance of this, stated with the estimate: 85%; the middle value lies on the limit itself.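

No step can be read from compound 2 to compound 3, as both stand only at a limit: the limit of > 100000 nM in this assay, at which 3 of the 3 values shown sit. The compounds shown leave open what number each would give, and whether fluoro in place of hydroxy changes anything.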